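Piperazine heteroaryl swap in the quinazoline series

The compounds below may be only part of what the source reports. "The series", "measured", "known", "first", "only" and "open" are said of these compounds alone.

Working notes on the series. The shared core is a quinazoline carrying a piperazine, and the heteroaryl on the distal piperazine nitrogen is the variable part. In an assay on brain for binding affinity to Adrenergic receptor alpha-1 (Rattus norvegicus) (a lower number here means a stronger inhibitor, a higher number a weaker inhibitor), compound 1 `COc1cc2nc(N3CCN(c4ccncn4)CC3)nc(N)c2cc1OC` gives 0.27 nM. Compound 2 `COc1ccnc(N2CCN(c3nc(N)c4cc(OC)c(OC)cc4n3)CC2)n1` gives 0.19 nM in this assay. Compound 3 `COc1cc2nc(N3CCN(c4ccnc(Oc5ccccc5)n4)CC3)nc(N)c2cc1OC` gives 0.24 nM in this assay. Compound 2 holds the lowest of the three numbers, but compound 3 and compound 1 both lie within the scatter of it, so no order among the three is established.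

Compound 4 `COc1nc(OC)nc(N2CCN(c3nc(N)c4cc(OC)c(OC)cc4n3)CC2)n1` is not yet measured. It differs from compound 2 by 4,6-dimethoxy-1,3,5-triazin-2-yl in place of 4-methoxypyrimidin-2-yl on an amine nitrogen in a ring.

Within the data shown here, two measured steps bear on this. The change of heteroaryl on the same ring nitrogen gave a 1.4-fold lower number from compound 1 to compound 2 (0.15 log units; within the scatter), and the addition of a group on that heteroaryl gave a 1.1-fold lower number from compound 1 to compound 3 (0.05 log units; within the scatter). Both lie within the scatter, and the change from compound 2 to compound 4 is again a modification of the heteroaryl on that ring nitrogen. The expectation in this assay is therefore no step beyond the scatter, a 1.3-fold higher number from compound 2 to compound 4 (0.12 log units; within the scatter).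

Compound 4 is estimated at 0.25 nM in this assay, with the range expected to run from 0.09 nM to 0.7 nM.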

Compound 4, inhibition constant: 0.08 nM
Compound 4: the middle estimate sits 3.1-fold (0.49 log units) above what was measured, and the stated range ends above it.
By their numbers in this assay, from the lowest: compound 4; then compounds 2, 3 and 1 (each within the scatter of the next).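

The heteroaryl on this ring nitrogen, three ring bonds from the ring atom that bears a large group, is not as flat in this assay as the first three compounds suggested: the series now has steps beyond the scatter, namely (a 2.4-fold lower number from compound 2 to compound 4 (0.38 log units; beyond the scatter)) and (a 3.4-fold lower number from compound 1 to compound 4 (0.53 log units; beyond the scatter)), both modest and both toward a lower number. The gain appears only with 4,6-dimethoxy-1,3,5-triazin-2-yl, whose ring has 3 hetero atoms and which carries a second methoxy group, whereas neither 4-methoxypyrimidin-2-yl nor the phenoxy group on the pyrimidine of compound 3 moved the number beyond the scatter from compound 1. No measurement is available that would account for this gain.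

The compounds shown do not separate the third ring hetero atom from the second methoxy group, since both enter together in the one step from compound 2 to compound 4. Also open, as far as these compounds go, is whether the lower number would persist with an amine or a longer alkoxy chain such as butoxy in place of a methoxy group on the triazine ring.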